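Replacing the hydroxy of compound 2 with a substituted aminophenyl

This account rests on a few compounds, and the source may have more. Where it says the series, first, only, none or still open, it means among the compounds named here.

Measured compounds:
compound 1, `Nc1ccccc1NC(=O)c1ccc(CNC2=NC(=O)C(Cc3c[nH]c4ccccc34)N2)cc1`: > 20000 nM
compound 2, `O=C(NO)c1ccc(CNc2nccc(-c3cccnc3)n2)cc1`: 42 nM

Among the measured compounds shown here, compound 2 is the only compound with a numerical result in an assay on isolated protein for inhibition of protein deacetylase HDAC6 (Homo sapiens), read by fluorescence, with stated times of 3 h and 60 min (a lower number here means a stronger inhibitor, a higher number a weaker inhibitor), where compound 2 gives 42 nM. Compound 1 gives only a limit in this assay, reported as > 20000 nM, so no number stands beside it; it sits at the limit of > 20000 nM in this assay, at which 1 of the 2 values shown sits.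

Compound 3, `Nc1cc(O)ccc1NC(=O)c1ccc(CNc2nccc(-c3cccnc3)n2)cc1`, has not yet been measured. It differs from compound 2 in one place: 2-amino-4-hydroxyphenyl in place of hydroxy on an amide-type nitrogen. The whole remaining part of compound 2, including the pyridine-bearing aminopyrimidine linked through the benzylic amine, is kept.

For the measured compounds named here, no measured pair shows this exact change, so its size can only be expected. Compound 1 carries an amino-bearing phenyl on the same amide-type nitrogen and reaches only the limit in this assay. On that basis the step from compound 2 to compound 3 is expected to be a large loss, a 360-fold higher number from compound 2 to compound 3 (2.55 log units; beyond the scatter), well beyond the usual scatter. Compound 3 is therefore estimated at 15000 nM in this assay, with a range from 3000 nM to 60000 nM, and a real chance that only a limit is reported.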

Compound 3, half-maximal inhibitory concentration: > 20000 nM
Compound 3: only a limit was reported; the forecaster's own chance of this, stated with the estimate: 55%; middle value at least 1.3-fold (0.12 log units) away from the limit.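

With compound 3 the amide-type nitrogen can be read through a change in one place, with the rest of compound 2 kept: in this assay the swap of hydroxy for 2-amino-4-hydroxyphenyl gives an at least 470-fold higher number from compound 2 to compound 3 (2.67 log units; beyond the scatter) in this series, a large loss of inhibition that lies beyond the scatter. Compound 3 gives > 20000 nM in this assay and this is a limit, not a number, so the step states only a least size and the full size of the loss stays unread. Compound 1 differs from compound 2 in more than one place, so only this pair ties the loss to the group on this nitrogen, and compound 3 now joins compound 1 at the same limit: the limit of > 20000 nM in this assay, at which 2 of the 3 values shown sit.

The compounds shown leave open which part of the 2-amino-4-hydroxyphenyl group goes with the loss, the ring itself, its amino or its hydroxy. An unsubstituted phenyl, or a small group such as methyl or methoxy on the same amide-type nitrogen, would show how much of the change the ring alone accounts for, and whether any group there keeps a number in this assay.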